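The source may report more compounds than this note shows. Statements on the series, on what has been measured and on what is new or still open speak of the compounds shown alone.

Measured compounds in a functional assay on HT-29 cells (Homo sapiens) for cytotoxicity, read by MTT assay, with a stated time of 72 h; a higher number here means a weaker inhibitor, a lower number a stronger inhibitor:
Compound 1, `COc1ccc(NC(=O)CN2CCN(c3nnc(Cc4ccccc4)c4ccccc34)CC2)cc1OC`, gives 145000 nM.
Compound 2, `O=C(CN1CCN(c2nnc(Cc3ccccc3)c3ccccc23)CC1)Nc1ccc(F)c(Cl)c1`, gives 13300 nM.
Compound 3, `O=C(CN1CCN(c2nnc(Cc3ccccc3)c3ccccc23)CC1)Nc1ccc(Br)cc1`, gives 60200 nM.

Compound 3 stands second highest of the three numbers in this assay, a 2.4-fold lower number from compound 1 to compound 3 (0.38 log units; beyond the scatter), while a 4.5-fold higher number from compound 2 to compound 3 (0.66 log units; beyond the scatter). Compound 4 is `O=C(CN1CCN(c2nnc(Cc3ccccc3)c3ccccc23)CC1)Nc1cccc(F)c1`; the change from compound 3 is 3-fluorophenyl in place of 4-bromophenyl on an amide-type nitrogen. For the measured compounds named here, two measured steps bear on this position on the amide-type nitrogen: an 11-fold lower number from compound 1 to compound 2 (1.04 log units; beyond the scatter) and a 4.5-fold higher number from compound 2 to compound 3 (0.66 log units; beyond the scatter), both beyond the scatter, so this part of the molecule moves the number noticeably. Going by the values given here, no measured step trades 4-bromophenyl for 3-fluorophenyl directly, so the direction is uncertain; a modest step toward a lower number, a 1.7-fold lower number from compound 3 to compound 4 (0.24 log units; within the scatter), is expected for compound 4. Compound 4 is estimated at 35000 nM, within 12000 nM to 100000 nM.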

Compound 4, half-maximal inhibitory concentration: 95000 nM
The estimate for compound 4 lay 2.7-fold (0.43 log units) below the measured number; low and high end bracket the measured number.
By their numbers in this assay, from the lowest: compound 2; then compounds 3, 4 and 1 (each within the scatter of the next, the first and the last beyond it).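

The 3-fluorophenyl group on the amide-type nitrogen gives a number within the scatter of both the 4-bromophenyl group (a 1.6-fold higher number from compound 3 to compound 4 (0.20 log units; within the scatter)) and the 3,4-dimethoxyphenyl group (a 1.5-fold lower number from compound 1 to compound 4 (0.18 log units; within the scatter)). The 3-chloro-4-fluorophenyl group stays clearly apart (a 7.1-fold higher number from compound 2 to compound 4 (0.85 log units; beyond the scatter)), so the fluorine of the 3-fluorophenyl group alone does not reproduce the lower number of compound 2. No measurement at hand explains this gap. The compounds shown leave open whether a 3-chlorophenyl group, a 4-fluorophenyl group or a pyridine ring on the amide-type nitrogen would keep that lower number.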